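Swapping the amide nitrogen side chain for a hydroxycyclohexyl ring

The source may report more compounds than this note shows. Statements on the series, on what has been measured and on what is new or still open speak of the compounds shown alone.

Of the compounds shown here, two sharing one core have been tested so far. Compound 1 `Cc1nc(-c2nc[nH]n2)ccc1-c1cnc2c(n1)N(CCC1CCOCC1)C(=O)CN2` gives, in an ADME assay on the whole organism for pharmacokinetics, with Rattus norvegicus as the target, at a dose of 5 mg/kg by the oral route (on this read-out higher numbers stand for higher exposure at the dose given and lower numbers for lower exposure), a value of 618 ng.h/mL, the highest of the two numbers. Compound 2 `O=C1CN(CCC2CCOCC2)c2nc(-c3ccc(-c4nc[nH]n4)nc3)cnc2N1` gives in this assay a value of 73.2 ng.h/mL, a lower exposure than compound 1 by a gap beyond the usual scatter. Compound 3 `Cc1nc(-c2nc[nH]n2)ccc1-c1cnc2c(n1)N([C@H]1CC[C@@H](O)CC1)C(=O)CN2` has not been measured yet. It differs from compound 1 in one place: 4-hydroxycyclohexyl in place of 2-(oxan-4-yl)ethyl on an amide-type nitrogen in a ring. For the measured compounds named here, no measured pair shows such a change, so there is nothing to say about its size from data of this kind. A small downward step is expected, a 1.5-fold lower number from compound 1 to compound 3 (0.19 log units; within the scatter), which may well lie within the scatter. Compound 3 is therefore estimated to give 400 ng.h/mL in this assay, with a range from 120 ng.h/mL to 1200 ng.h/mL.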

Compound 3, area under the concentration-time curve: 28.5 ng.h/mL
Compound 3: the middle estimate sits 14-fold (1.15 log units) above what was measured; the measured number lies below the stated range.
By their numbers in this assay, from the lowest: compound 3; then compound 2; then compound 1.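

Compound 1's side chain on the amide-type nitrogen has a large bearing on exposure in this assay: putting 4-hydroxycyclohexyl in place of 2-(oxan-4-yl)ethyl gives a 22-fold lower number from compound 1 to compound 3 (1.34 log units; beyond the scatter) as the outcome of this single change. By simple counts the swap looks modest, as one six-membered non-aromatic ring with an oxygen in the group gives way to another, although the entering group brings a hydrogen-bond donor and the leaving group has none. Nothing measured here says what lies behind this drop.

The ring, the chain and the hydroxyl differ all at once, so the compounds shown cannot assign the step to any one of them. A plain cyclohexyl ring, a 2-cyclohexylethyl chain or an amine in place of the hydroxyl would each help to separate these parts.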